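Swapping an amine side chain for an ether in compound 4

The source may hold more compounds than are shown below. What is called first, only, known or untested is meant among the compounds shown, and "the series" means these compounds.

Of the compounds shown here, three sharing one core have been measured in an in vitro assay on 293-EBNA cells for binding affinity to corticotropin-releasing factor receptor 1 (Homo sapiens); a lower number here means a stronger inhibitor, a higher number a weaker inhibitor. Compound 1 `CCC(COC)N(C)c1nc(C)nc2c1nnn2-c1ccc(C(C)C)cc1Br` gives 11.2 nM, compound 2 `COCC(COC)Nc1nc(C)nc2c1nnn2-c1ccc(C(C)C)cc1Br` gives 10.3 nM, and compound 3 `CCCC(CN(C)C)Nc1nc(C)nc2c1nnn2-c1ccc(C(C)C)cc1Br` gives 38.7 nM, which is the highest of the three numbers, with both of the others sitting beyond the scatter below it.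

Compound 4 `CCC(COC)Oc1nc(C)nc2c1nnn2-c1ccc(C(C)C)cc1Br` is reached from compound 3 by a group of 7 heavy atoms (5 carbon, 2 oxygen; no ring) in place of a group of 9 heavy atoms (7 carbon, 2 nitrogen; no ring), on an aromatic carbon: the leaving group carries a hydrogen-bond donor, the entering 1-(methoxymethyl)propoxy group carries none. For the measured compounds named here, two measured steps bear on this. a 3.8-fold higher number from compound 2 to compound 3 (0.57 log units; beyond the scatter) shows that trading a chain with two oxygens for the chain with two nitrogens weakened binding, and a 3.5-fold higher number from compound 1 to compound 3 (0.54 log units; beyond the scatter) points the same way. Going by the values given here, compound 4 moves back toward an oxygen-bearing chain, so a step of a similar size in the opposite direction is expected; the change from an amine link to an ether link has no measured precedent here, which widens the range. Compound 4 is expected to give 15 nM, between 6 nM and 45 nM, a step of a 2.6-fold lower number from compound 3 to compound 4 (0.41 log units; beyond the scatter).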

Compound 4, inhibition constant: 1.9 nM
The estimate for compound 4 lay 7.9-fold (0.90 log units) above the measured number; measured number below the stated range.
By their numbers in this assay, from the lowest: compound 4; then compounds 2 and 1 (each within the scatter of the next); then compound 3.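

The clearest reading comes from a 5.9-fold lower number from compound 1 to compound 4 (0.77 log units; beyond the scatter) in this assay for a change that keeps the same side chain and swaps only its methylated nitrogen link for an oxygen link, showing that the linking atom on this aromatic carbon matters in a way the earlier, all-nitrogen-linked compounds could not show. The other two comparisons, a 5.4-fold lower number from compound 2 to compound 4 (0.73 log units; beyond the scatter) and a 20-fold lower number from compound 3 to compound 4 (1.31 log units; beyond the scatter) make compound 4 the strongest inhibitor of the four, with every step to it beyond the scatter. Nothing here explains this gain.

On these data alone, it remains open whether the oxygen link would bring a similar gain to other side chains, such as the dimethylamino-bearing chain of compound 3. Nor do these compounds show how a sulfur link would compare with the oxygen link.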